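The source may report more compounds than this note shows. Statements on the series, on what has been measured and on what is new or still open speak of the compounds shown alone.

Measured compounds:
- compound 1 `C=C1C(=O)O[C@H]2[C@H]1CC/C(COC(=O)Cn1cc(F)c(=O)n(Cc3ccccc3)c1=O)=C\CC[C@@]1(C)O[C@@H]21`: 4270 nM
- compound 2 `C=C1C(=O)O[C@H]2[C@H]1CC/C(COC(=O)Cn1cc(F)c(=O)n(Cc3ccc(Br)cc3)c1=O)=C\CC[C@@]1(C)O[C@@H]21`: 3240 nM
- compound 3 `C=C1C(=O)O[C@H]2[C@H]1CC/C(COC(=O)Cn1cc(F)c(=O)n(Cc3cccc(F)c3)c1=O)=C\CC[C@@]1(C)O[C@@H]21`: 3700 nM

All three share one core and were tested in a functional assay on Bel7402/5-FU cells (Homo sapiens) for antiproliferative activity, read by MTT assay, with a stated time of 72 h; on this read-out higher numbers stand for weaker inhibition and lower numbers for stronger inhibition. Compound 3 has no separate rank among them. Its two comparisons are a 1.1-fold higher number from compound 2 to compound 3 (0.06 log units; within the scatter) and a 1.2-fold lower number from compound 1 to compound 3 (0.06 log units; within the scatter), so it sits in one tight group with the other two compounds.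

The next compound is compound 4 `C=C1C(=O)O[C@H]2[C@H]1CC/C(COC(=O)Cn1cc(F)c(=O)n(Cc3ccccc3F)c1=O)=C\CC[C@@]1(C)O[C@@H]21`. It has the same atoms as compound 3, joined differently: 2-fluorophenyl in place of 3-fluorophenyl on a saturated chain carbon bound to an aromatic nitrogen.

Among the compounds with values here, no measured compound carries the 2-fluorophenyl group, so the closest evidence is indirect. Adding a fluoro group to the aromatic ring gave a 1.2-fold lower number from compound 1 to compound 3 (0.06 log units; within the scatter). Bromo in the same kind of exchange gave a 1.3-fold lower number from compound 1 to compound 2 (0.12 log units; within the scatter). Neither step rises above the scatter, so these few changes to the aromatic ring give no sign of a sensitive spot. Three compounds are a small sample, however, and a new fluoro placement could still behave differently.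

In this assay, no step beyond the scatter is therefore expected, and no direction can be favoured. The expected result is a 1.0-fold lower number from compound 3 to compound 4 (0.01 log units; within the scatter). For compound 4, the estimate is 3600 nM, with an expected range from 2000 nM to 6300 nM.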

Compound 4, half-maximal inhibitory concentration: 3830 nM
The estimate for compound 4 lay 1.1-fold (0.03 log units) below the measured number; the range from low to high includes it.
By their numbers in this assay, from the lowest: compounds 2, 3, 4 and 1 (each within the scatter of the next).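

Within the data shown here, exchanging 3-fluorobenzyl for 2-fluorobenzyl keeps the same atoms and alters only how the fluoro group is placed on the ring, a kind of change the earlier compounds did not include, and in this assay it gave a 1.0-fold higher number from compound 3 to compound 4 (0.01 log units; within the scatter) and so no effect that stands out from the scatter. The wider comparisons read the same way, with a 1.2-fold higher number from compound 2 to compound 4 (0.07 log units; within the scatter) and a 1.1-fold lower number from compound 1 to compound 4 (0.05 log units; within the scatter) showing that compounds with hydrogen, bromo or fluoro on this ring all form one tight group. No other measurement is available to help explain this flat picture.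

On these data alone, all four compounds differ only in a hydrogen or halogen on the benzyl ring, so it remains open whether the same flat picture would hold with a methoxy group, an amine or a carboxylic acid on that ring, or with a longer chain in place of the benzyl group. The shared core is also identical throughout, so these compounds say nothing about how changes there would read in this assay.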